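Fluorine on the benzyl arm of a prostacyclin synthase inhibitor

The compounds below may be only part of what the source reports. "The series", "measured", "known", "first", "only" and "open" are said of these compounds alone.

Compound 1 `CC(C)(Oc1ccccc1)C1OCC(C/C=C\CCC(=O)O)C(c2cccnc2)O1` is the parent of the set. In an assay for inhibition of prostacyclin synthase (Homo sapiens), using microsomes (a higher number here means a weaker inhibitor, a lower number a stronger inhibitor), compound 1 gives 75000 nM. Compound 2 `CC(C)(Oc1ccc(F)cc1)C1OCC(C/C=C\CCC(=O)O)C(c2cccnc2)O1` carries the change (fluoro in place of hydrogen on an aromatic carbon), and in this assay compound 2 gives 2000 nM, so the step of a 38-fold lower number from compound 1 to compound 2 (1.57 log units; beyond the scatter) is a large one. Compound 3 `CC(C)(Cc1ccccc1)C1OCC(C/C=C\CCC(=O)O)C(c2cccnc2)O1` differs from compound 1 in its core by benzyl in place of phenoxy on a saturated chain carbon bound to two saturated chain carbons and a saturated ring carbon; in this assay compound 3 gives 13000 nM, and the step of a 5.8-fold lower number from compound 1 to compound 3 (0.76 log units; beyond the scatter) is modest. Between the two cores with a fluorine-free ring and the fluorinated phenoxy compound the step of a 6.5-fold higher number from compound 2 to compound 3 (0.81 log units; beyond the scatter) runs the other way.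

Compound 4 `CC(C)(Cc1ccc(F)cc1)C1OCC(C/C=C\CCC(=O)O)C(c2cccnc2)O1` has not yet been measured. It differs from compound 3 by fluoro in place of hydrogen on an aromatic carbon. This is the same change already seen from compound 1 to compound 2, and its place reads the same in both cases; only the core differs, as told above. Among the measured compounds shown here, because a 38-fold lower number from compound 1 to compound 2 (1.57 log units; beyond the scatter) was large, a marked drop is expected for compound 4 as well, though the single earlier instance sits on the phenoxy core rather than the benzyl core, so the expected step is set somewhat smaller than that one. The step expected from compound 3 to compound 4 is a 14-fold lower number from compound 3 to compound 4 (1.16 log units; beyond the scatter). Compound 4 is therefore estimated at 900 nM in this assay, between 200 nM and 4000 nM.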

Compound 4, half-maximal inhibitory concentration: 2000 nM
The estimate for compound 4 lay 2.2-fold (0.35 log units) below the measured number; measured number inside the range.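

In this assay, fluoro in place of hydrogen on the aromatic carbon lowers the number on both cores, but the size of the step does not carry over from one core to the other: the same change on two cores in this assay, a 38-fold lower number (1.57 log units; beyond the scatter) from compound 1 to compound 2 and a 6.5-fold lower number (0.81 log units; beyond the scatter) from compound 3 to compound 4, 5.8-fold (0.76 log units) apart, beyond the scatter of two such steps On the core of compound 3 the change gives a 6.5-fold lower number from compound 3 to compound 4 (0.81 log units; beyond the scatter), so the direction holds while the size is smaller, and the two fluorinated compounds end level, with no change at the digits printed from compound 2 to compound 4 (within the scatter), whereas the overall difference from the parent is a 38-fold lower number from compound 1 to compound 4 (1.57 log units; beyond the scatter). This shows that, for these two cores, the gain from this change depends on the core that carries it, but with one pair on each core it does not show what sets the difference, nor how large the step would be on any third core.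

The compounds shown leave open whether chloro or methoxy in the same place on the ring would lower the number as fluoro does, and whether such a group would also give steps of unequal size on the two cores. They also leave open whether a longer chain between the ring and the saturated chain carbon, in place of the benzyl or phenoxy link, would keep the fluoro step.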